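Moving the hydroxyl inward on a brominated adenine chain

A few compounds are considered here, and "the series" means these few. Any claim that something is new, unique, unknown or untested is made for them only; others in the source may bear on it.

Compound 1 `Nc1ncnc2c1ncn2C1CCC1` carries a cyclobutyl group, and in an assay on CHO cells for displacement of a labelled ligand from adenosine receptor A3 (Homo sapiens) (on this read-out higher numbers stand for weaker inhibition and lower numbers for stronger inhibition), compound 1 gives 33000 nM. Compound 2 `Nc1ncnc2ncn(CCCO)c12` bears a 3-hydroxypropyl chain instead; in this assay compound 2 gives > 100000 nM, which is a limit of the assay rather than a number. Compound 3 `Nc1ncnc2c1nc(Br)n2CCCO` keeps that chain and adds a bromine to the core; in this assay compound 3 gives 3200 nM, the lower of the two numbers shown, with the value of compound 1 lying beyond the usual scatter from it. Compound 4 `CC(O)Cn1c(Br)nc2c(N)ncnc21` has not been measured. It differs from compound 3 only in the chain: 1-hydroxyethyl in place of 2-hydroxyethyl on a saturated chain carbon bound to an aromatic nitrogen, so the same atoms are joined differently. Among the compounds with values here, no step between the measured compounds follows this kind of change, so only a small shift is expected here, perhaps a slight weakening, of a size not clearly beyond the scatter. The estimate is that compound 4 gives 5000 nM in this assay, between 1500 nM and 20000 nM. That expected number amounts to a step of a 1.6-fold higher number from compound 3 to compound 4 (0.19 log units; within the scatter).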

Compound 4, inhibition constant: >= 100000 nM
Compound 4 gave a limit, no number; the forecaster's own chance of this, stated with the estimate: 5%; at least 20-fold (1.30 log units) between middle value and limit.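

Read as 3-hydroxypropyl to 2-hydroxypropyl, this change adds and removes no atoms, yet in this assay it gives an at least 31-fold higher number from compound 3 to compound 4 (1.49 log units; beyond the scatter). Within the data shown here, it shows that, on a saturated chain carbon bound to an aromatic nitrogen, the way the same atoms are joined can matter far beyond the scatter, which the earlier compounds offered no pair to show. The value of compound 4 is a limit of the assay and not a number, so the step has a bound on one side only: the limit of >= 100000 nM in this assay, at which 1 of the 4 values shown sits.

The compounds shown leave open whether the same rearrangement would matter as much on a chain without the bromine on the core. They also leave open how an amine in place of the hydroxyl, or a longer chain carrying the hydroxyl, would read in this assay.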